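This account rests on a few compounds, and the source may have more. Where it says the series, first, only, none or still open, it means among the compounds named here.

Measured in an ADME assay on HEK293 cells (Homo sapiens) for cytotoxicity, read by reporter gene assay and resazurin assay, with a stated time of 48 h; on this read-out higher numbers stand for lower toxicity in this test and lower numbers for higher toxicity in this test:
compound 1, `O=C(Nc1ccc(Sc2nc3ccccc3s2)c(Cl)c1)c1ccccc1O`: 64000 nM
compound 3, `O=C(Nc1ccc(Sc2nc3ccccc3s2)cc1)c1ccccc1O`: 74000 nM
compound 2, `COc1c(Br)cc(Br)cc1C(=O)Nc1ccccc1`: > 100000 nM, which is a limit of the assay, not a number (the limit of > 100000 nM in this assay, at which 1 of the 3 values shown sits)

Compound 1 has the lowest of the two numbers, and compound 3 differs from it by a 1.2-fold higher number from compound 1 to compound 3 (0.06 log units; within the scatter), within the scatter. Compound 4, `O=C(Nc1ccc(Sc2nc3ccccc3s2)c(Cl)c1)c1cccc(Br)c1`, differs from compound 1 in one place: 3-bromophenyl in place of 2-hydroxyphenyl on a carbonyl carbon. Going by the values given here, no measured step touches the group on the carbonyl carbon; the only measured step, a 1.2-fold higher number from compound 1 to compound 3 (0.06 log units; within the scatter), changes a chloro on an aromatic carbon and stays within the scatter. Among the compounds with values here, compound 2 also carries bromine, but no single-point step links it to compound 1. No direction can therefore be read, and compound 4 is expected to sit close to compound 1, a 1.3-fold lower number from compound 1 to compound 4 (0.11 log units; within the scatter), estimated at 50000 nM with a range of 15000 nM to 100000 nM.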

Compound 4, half-maximal cytotoxic concentration: > 100000 nM
Compound 4: no number, only a limit; the forecaster's own chance of this, stated with the estimate: 25%; middle value at least 2.0-fold (0.30 log units) away from the limit.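

In this assay compound 4 gives only a limit of the assay, not a number. Going by these compounds alone, this is the first measured change to the group on the carbonyl carbon, and the step reads an at least 1.5-fold higher number from compound 1 to compound 4 (0.19 log units; that floor lies within the scatter), so 3-bromophenyl in place of 2-hydroxyphenyl gives no sign of higher toxicity in this test, while the true size of the step stays unknown. Compound 4 now shares its ceiling with compound 2: the limit of > 100000 nM in this assay, at which 2 of the 4 values shown sit.

Going by these compounds, how far compound 4 truly lies from compound 1 remains open. So does how a phenyl group bearing an amine or a carboxylic acid on the same carbonyl carbon would read.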